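Compound 3 to compound 4: a change of aryl group

This account rests on a few compounds, and the source may have more. Where it says the series, first, only, none or still open, it means among the compounds named here.

- compound 1 `COc1cc(C(=O)c2cn(-c3ccccc3)cc2-c2ccc(Br)cc2)cc(OC)c1OC`: 340 nM
- compound 2 `COc1cc(C(=O)c2cn(-c3ccccc3)cc2-c2cccc([N+](=O)[O-])c2)cc(OC)c1OC`: 50 nM
- compound 3 `COc1cc(C(=O)c2cn(-c3ccccc3)cc2-c2ccc([N+](=O)[O-])cc2)cc(OC)c1OC`: 590 nM

All three numbers come from a functional assay on MCF7 cells (Homo sapiens) for cytotoxicity, read by MTT assay, with a stated time of 96 h; on this read-out higher numbers stand for weaker inhibition and lower numbers for stronger inhibition. Compound 3, at 590 nM, sits at the high end of this small set, level within the scatter with its nearest neighbour: a 1.7-fold higher number from compound 1 to compound 3 (0.24 log units; within the scatter). The furthest neighbour lies well away: a 12-fold higher number from compound 2 to compound 3 (1.07 log units; beyond the scatter).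

Compound 4 `COc1cccc(-c2cn(-c3ccccc3)cc2C(=O)c2cc(OC)c(OC)c(OC)c2)c1` has not yet been measured. It carries 3-methoxyphenyl in place of 4-nitrophenyl on an aromatic carbon of a five-membered aromatic ring with 1 nitrogen (3-methoxyphenyl in place of 4-nitrophenyl on an aromatic carbon).

Compound 2, with 3-nitrophenyl, is the closest measured match to the entering group, and the large step of a 12-fold higher number from compound 2 to compound 3 (1.07 log units; beyond the scatter) is the main evidence here. The modest step of a 6.8-fold lower number from compound 1 to compound 2 (0.83 log units; beyond the scatter) points the same way. Among these three compounds, 3-nitrophenyl stands alone at the low number, and none goes against that reading. However, it rests on compound 2 only, and no methoxy group on this ring has been measured. Only part of the gap to compound 2 is therefore expected to be recovered.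

The expected change in this assay is modest and towards a lower number: a 4.9-fold lower number from compound 3 to compound 4 (0.69 log units; beyond the scatter). For compound 4 the estimated value is 120 nM, with an expected range of 30 nM to 450 nM.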

Compound 4, half-maximal inhibitory concentration: 180 nM
For compound 4 the middle estimate is 1.5-fold (0.18 log units) below the measured one; low and high end bracket the measured number.
By their numbers in this assay, from the lowest: compound 2; then compounds 4, 1 and 3 (each within the scatter of the next, the first and the last beyond it).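

In this assay, 3-methoxyphenyl at this position is a clear gain over 4-nitrophenyl (a 3.3-fold lower number from compound 3 to compound 4 (0.52 log units; beyond the scatter)), yet with methoxy in place of nitro it does not match 3-nitrophenyl (a 3.6-fold higher number from compound 2 to compound 4 (0.56 log units; beyond the scatter)), so the low number of compound 2 does not carry over to every group of this shape and compound 2 remains lowest of the four. 3-Methoxyphenyl and 4-bromophenyl cannot be told apart at this position (a 1.9-fold lower number from compound 1 to compound 4 (0.28 log units; within the scatter), within the scatter), which shows that a group without nitro can sit level with compound 1 while a nitro group can lie on either side of it, depending on where it stands on the aryl ring. No measurement at hand gives a reason for any of these differences.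

From the compounds shown here alone, only nitro is seen in two ring places, while methoxy and bromo each appear in one, so how much of the gain from compound 3 to compound 4 belongs to the group and how much to its place remains open. Going by these compounds, how an amine, a carboxylic acid or a longer chain such as ethoxy on this aryl ring would compare with methoxy and nitro also remains open.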